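This account rests on a few compounds, and the source may have more. Where it says the series, first, only, none or still open, it means among the compounds named here.

Compound 2 `COc1cc(-c2cc(C(=O)/C=C/c3ccc(C)cc3)nc3cc(-c4ccccc4)nn23)cc(OC)c1OC` is the weaker-looking of the two measured entries: in a functional assay on A549 cells (Homo sapiens) for antiproliferative activity, read by MTT assay, with a stated time of 24 h (on this read-out higher numbers stand for weaker inhibition and lower numbers for stronger inhibition), compound 2 gives 20000 nM, the highest of the two numbers, while compound 1 `COc1cc(-c2cc(/C=C/C(=O)c3ccc(C)cc3)nc3cc(-c4ccccc4)nn23)cc(OC)c1OC` gives 19400 nM in this assay, and the two values lie within the scatter of each other. For the measured compounds named here, the only measured step, a 1.0-fold higher number from compound 1 to compound 2 (0.01 log units; within the scatter), shows that turning the enone bridge around leaves the number essentially unchanged.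

Compound 3 `COc1cc(-c2cc(/C=C/C(=O)c3ccc(Cl)cc3)nc3cc(-c4ccccc4)nn23)cc(OC)c1OC` differs from compound 2 by 2-((4-chlorophenyl)carbonyl)ethenyl in place of (2-(4-methylphenyl)ethenyl)carbonyl on an aromatic carbon. This change reverses the bridge again, bringing compound 3 back to the arrangement of compound 1, and at the same time replaces the methyl on the distal ring with chlorine. Going by the values given here, the step from compound 1 to compound 2 bears on the first part and was within the scatter; no measured pair speaks to the methyl-to-chlorine exchange. The step of a 1.1-fold lower number from compound 2 to compound 3 (0.05 log units; within the scatter) is therefore expected to stay within the scatter, with no direction predicted beyond it. Compound 3 is estimated to give 18000 nM in this assay, in an expected range from 7000 nM to 50000 nM.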

Compound 3, half-maximal inhibitory concentration: 15500 nM
For compound 3 the middle estimate is 1.2-fold (0.06 log units) above the measured one; measured number inside the range.
By their numbers in this assay, from the lowest: compounds 3, 1 and 2 (each within the scatter of the next).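

For the compounds shown here, compound 3 gives the first reading on chloro in place of methyl on an aromatic carbon: in this assay the step is a 1.3-fold lower number from compound 1 to compound 3 (0.10 log units; within the scatter) and lies within the scatter, so with the bridge arrangement held as in compound 1, this exchange does not separate the two compounds. The replacement of (2-(4-methylphenyl)ethenyl)carbonyl by 2-((4-chlorophenyl)carbonyl)ethenyl, which turns the bridge around and exchanges the substituent in one move, gives a 1.3-fold lower number from compound 2 to compound 3 (0.11 log units; within the scatter) and also stays within the scatter, so the two alterations made together leave these compounds indistinguishable in this read-out. No supporting evidence is available to explain these readings.

As far as these compounds go, all three compounds stay within the scatter of one another, and they carry only methyl or chloro on that outer ring, so it remains open whether a methoxy group, an amine or a carboxylic acid there would give a number beyond the scatter. From the compounds shown here alone, it is also open whether a bridge of another kind, such as a saturated chain or an amide in place of the enone, would leave the number where these three compounds stand.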